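Fluoro in place of hydrogen on compound 3

The compounds below may be only part of what the source reports. "The series", "measured", "known", "first", "only" and "open" are said of these compounds alone.

The measured compounds in a physicochemical assay for solubility, read by nephelometry, measured as kinetic solubility, at pH 2, tested at 10 mg/mL (a higher number here means a more soluble compound, a lower number a less soluble compound), stand as follows:
- compound 1 `Cc1c(F)cccc1C(=O)Nc1cc(Cl)ccn1` gives 12.5 ug/mL as a number
- compound 2 `Cc1c(F)cccc1C(=O)Nc1ccccn1` gives 50 ug/mL as a number
- compound 3 `Cc1ccnc(NC(=O)c2ccccc2C)c1` gives > 100 ug/mL as a limit

Compound 3 reports > 100 ug/mL in this assay and that value is a limit, not a number. Compound 4 `Cc1ccnc(NC(=O)c2cccc(F)c2C)c1` carries fluoro in place of hydrogen on an aromatic carbon and is still unmeasured. For the measured compounds named here, one measured step bears on this change: hydrogen in place of chloro on an aromatic carbon, a modest step beyond the scatter with a 4.0-fold higher number from compound 1 to compound 2 (0.60 log units; beyond the scatter) as its size. Read in reverse, and with fluoro for chloro, it leads to the expectation of a modest fall. The estimated change is an at least 2.0-fold lower number from compound 3 to compound 4 (0.30 log units; that floor lies within the scatter) and it starts from a limit. For compound 4 an estimated value of 50 ug/mL is expected, with a range from 20 ug/mL to 100 ug/mL in this assay here.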

Compound 4, solubility: > 100 ug/mL
Compound 4 was reported as a limit; the forecaster's own chance of this, stated with the estimate: 25%; middle value at least 2.0-fold (0.30 log units) from the limit.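

In this assay, compound 4 gives > 100 ug/mL, a limit and not a number, so fluoro ortho to a methyl group does not take the compound off that limit. The step from hydrogen to fluoro cannot be read, because compound 3 and compound 4 both sit at it: the limit of > 100 ug/mL in this assay, at which 2 of the 4 values shown sit. The step of methyl in place of hydrogen is an at least 2.0-fold higher number from compound 2 to compound 4 (0.30 log units; that floor lies within the scatter), and that of methyl in place of chloro is an at least 8.0-fold higher number from compound 1 to compound 4 (0.90 log units; beyond the scatter).

As far as these compounds go, the numbers behind the two limits stay open, and with them the size of the fluoro step. From the compounds shown here alone, it also remains open how an amine or a carboxylic acid on this aromatic carbon would read.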